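This account rests on a few compounds, and the source may have more. Where it says the series, first, only, none or still open, it means among the compounds named here.

Notes on the series. Compound 1 `CCCCCCCCCCCCCC[C@H](OCOC)[C@H](CO)NC(=O)OC(C)(C)C` gives -5.67% in a functional assay on MDA-MB-231 cells (Homo sapiens) for antiproliferative activity, read by sulforhodamine B assay, with a stated time of 48 h, tested at 10 uM; a higher number here means more inhibition at the concentration tested (going by the name of the read-out), a lower number less inhibition. Compound 2 `CCCCCCCCCCCCCC[C@H](OCOC)[C@H](CN(CC)CC)NC(=O)OC(C)(C)C` gives 0.84% in this assay; the move from hydroxy to diethylamino, a number 6.5 percentage points higher from compound 1 to compound 2 (within the scatter), stays within the scatter, so compound 2 and compound 1 cannot be told apart here. Compound 3 `CCCCCCCCCCCCCC[C@H](OCOC)[C@H](CN(C(C)C)C(C)C)NC(=O)OC(C)(C)C` differs from compound 2 by diisopropylamino in place of diethylamino on a saturated chain carbon, two bonds along the chain from an amide-type nitrogen. Within the data shown here, only the step from compound 1 to compound 2 touches this position, and it was flat, so no step beyond the scatter is expected in this assay. Compound 3 is estimated at 2%, between -10% and 14%, an expected step of a number 1.2 percentage points higher from compound 2 to compound 3 (within the scatter).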

Compound 3, a percentage reported as inhibition, at one concentration (the size of the read-out at that concentration, not a potency): 31%
Compound 3: middle estimate off by 29 percentage points, on the low side; measured number outside the range, above it.
By their numbers in this assay, from the lowest: compounds 1 and 2 (each within the scatter of the next); then compound 3.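

This position is not flat in this assay: diisopropylamino in place of diethylamino gives a number 30.2 percentage points higher from compound 2 to compound 3 (beyond the scatter) and so separates two closely related amines, which the earlier step could not show. Diisopropylamino in place of hydroxy gives a number 36.7 percentage points higher from compound 1 to compound 3 (beyond the scatter) and stands apart from the step to diethylamino, so among the compounds shown the rise goes with diisopropylamino alone, not with any amine here. No measurement on hand accounts for this.

Open, going by these compounds, is whether dicyclohexylamino or piperidine in this place would go further, and where the unsubstituted primary amine would fall.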